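The source may hold more compounds than are shown below. What is called first, only, known or untested is meant among the compounds shown, and "the series" means these compounds.

Compound 1 `O=C(Nc1ccc(C(F)(F)F)cc1)NC1CCN(C(=O)C2=COCC2)CC1` stands lowest of the three compounds measured: in a physicochemical assay for solubility, read by mass spectrometry, in phosphate buffer, with a stated time of 24 h, at pH 7.4 (a lower number here means a less soluble compound, a higher number a more soluble compound), compound 1 gives 2.3 ug/mL. The nearest number belongs to compound 3 `CC[C@H](C)C(=O)N1CCC(CC(=O)Nc2ccc(OC(F)(F)F)c(F)c2)CC1`, which in this assay gives 21 ug/mL, and the furthest to compound 2 `O=C(CC1CCN(C(=O)C2CC2)CC1)Nc1ccc(OC(F)(F)F)c(F)c1`, which in this assay gives 715 ug/mL. Compounds 2 and 3 share a core that compound 1 does not, so their numbers frame compound 1 without belonging to the same series.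

Compound 4 `O=C(Nc1ccc(C(F)(F)F)cc1)NC1CCN(C(=O)C2CCCOC2)CC1` differs from compound 1 in one place: a group of 6 heavy atoms (5 carbon, 1 oxygen; one six-membered non-aromatic ring with 1 hetero atom) in place of a group of 5 heavy atoms (4 carbon, 1 oxygen; one five-membered non-aromatic ring with 1 hetero atom), on a carbonyl carbon. Going by the values given here, the only step measured between compounds differing in one place is a 34-fold lower number from compound 2 to compound 3 (1.53 log units; beyond the scatter), sec-butyl in place of cyclopropyl. Among the compounds with values here, that change also sits on a carbonyl carbon, but on another core and with another pair of groups, so it shows only that a single exchange at such a carbon can move solubility far beyond the scatter, in either direction in principle. Within the data shown here, no measured pair exchanges one ring with one hetero atom for another. The exchange from compound 1 to compound 4 keeps one oxygen in a non-aromatic ring and adds one carbon, so the step is expected to be small, at most near the scatter. Compound 4 is therefore expected to give about 4 ug/mL in this assay, with a range from 1.2 ug/mL to 13 ug/mL. The expected step is a 1.7-fold higher number from compound 1 to compound 4 (0.24 log units; within the scatter).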

Compound 4, solubility: 1.1 ug/mL
Estimate against measurement, compound 4: 3.6-fold (0.56 log units) above; measured number below the stated range.
By their numbers in this assay, from the lowest: compound 4; then compound 1; then compound 3; then compound 2.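

On the core of compound 1, oxan-3-yl in place of the five-membered ring with its double bond, on a carbonyl carbon whose other neighbours are amide-type nitrogen in a ring, gives in this assay a 2.1-fold lower number from compound 1 to compound 4 (0.32 log units; beyond the scatter), a modest step that lies beyond the usual scatter. Going by these compounds alone, this is the only step read on this core, and it shows that the position responds even to a ring-for-ring exchange that keeps one hetero atom in the ring and leaves the counts of hydrogen-bond donors and acceptors unchanged. Nothing in hand bears on what lies behind this step, which stands as an observation on a single pair.

Ring size and the double bond change together in this pair, so the compounds shown do not tell the two apart, and a six-membered ring with a double bond or a five-membered ring without one would be needed to do so. From the compounds shown here alone, how this assay reads with an open-chain amine or a carboxylic acid on this carbonyl carbon also remains open, on this core as on any other.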